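Removing One Methoxy Group: What to Expect

The compounds below may be only part of what the source reports. "The series", "measured", "known", "first", "only" and "open" are said of these compounds alone.

Of the compounds shown here, two have been tested in a functional assay on the whole organism (strain Kunming) with Mus musculus as the target, with a stated time of 0.5 h, at a dose of 100 mg/kg by the intraperitoneal route; on this read-out higher numbers stand for a weaker effect at the one dose given and lower numbers for a stronger effect. Compound 1 `COc1cc(OC)c(OC)cc1/C=C/COC(=O)/C=C/c1ccc(OC)c(OC)c1` gives 100% in this assay, and compound 2 `COc1cc(OC)c(OC)cc1/C=C/COC(=O)/C=C/c1cc(OC)c(OC)c(OC)c1OC` gives 75%, the lower of the two numbers and so the stronger effect, a gap beyond the usual scatter. Compound 3 `COc1cc(OC)c(OC)cc1/C=C/COC(=O)/C=C/c1cc(OC)c(OC)c(OC)c1` differs from compound 2 by hydrogen in place of methoxy on an aromatic carbon. For the measured compounds named here, no single-change step between measured compounds exists to guide the size of the shift in this assay, so the expectation rests on the two values alone. The step of a number 10 percentage points higher from compound 2 to compound 3 (within the scatter) is expected to be small, towards a higher number. Compound 3 is expected to give 85%, within 65% to 100%.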

Compound 3, a percentage reported as activity, at one dose (the size of the read-out at that dose, not a potency): 100%
Compound 3: the middle estimate sits 15 percentage points below what was measured; measured number inside the range.
By their numbers in this assay, from the lowest: compound 2; then compounds 1 and 3 (each within the scatter of the next).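

In this assay, hydrogen in place of the methoxy ortho to a large group gives a number 25 percentage points higher from compound 2 to compound 3 (beyond the scatter), so the stronger effect of compound 2 is lost with this one group. Methoxy in place of hydrogen on an aromatic carbon gives no change at the digits printed from compound 1 to compound 3 (within the scatter), so among these compounds a methoxy does not count equally at every aromatic carbon. No measurement here explains this difference. Still open, as far as these compounds go, is whether a hydroxyl, an amine or a longer ether chain at this carbon would match methoxy, and a single dose gives no potency.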